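Cytotoxicity limits across one series of analogues

The compounds below may be only part of what the source reports. "The series", "measured", "known", "first", "only" and "open" are said of these compounds alone.

Compound 1 `CCc1c(Cc2c(Cl)cccc2Cl)nc(SCC(=O)c2ccc(OC)cc2)[nH]c1=O`: in an ADME assay on MT4 cells (Homo sapiens) for cytotoxicity, read by MTT assay (on this read-out higher numbers stand for lower toxicity in this test and lower numbers for higher toxicity in this test), compound 1 gives only a limit, > 54000 nM.
Compound 2 `COc1ccc(C(=O)CSc2nc(Cc3c(Cl)cccc3Cl)c(C(C)C)c(=O)[nH]2)cc1`: in this assay compound 2 gives only a limit, > 14000 nM.
Compound 3 `Cc1c(Cc2c(F)cccc2Cl)nc(SCC(=O)c2ccccc2)[nH]c1=O`: in this assay compound 3 gives only a limit, > 12000 nM.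

All three values are limits, as the limit of > 12000 nM in this assay, at which 1 of the 3 values shown sits, the limit of > 14000 nM in this assay, at which 1 of the 3 values shown sits, and the limit of > 54000 nM in this assay, at which 1 of the 3 values shown sits, show. The change methyl in place of hydrogen on a saturated chain carbon bound to an aromatic carbon and a saturated chain carbon gives the step that the two limits leave unreadable from compound 1 to compound 2, which the two limits leave unreadable. Compound 4 `CCc1c(Cc2c(F)cccc2Cl)nc(SCC(=O)c2ccccc2)[nH]c1=O` is not yet measured; it differs from compound 3 by methyl in place of hydrogen on a saturated chain carbon bound to an aromatic carbon, the same kind of change, here on a saturated chain carbon bound to an aromatic carbon rather than one bound also to a saturated chain carbon. The difference between the cores of compound 1 and compound 3 is not broken down here. Since compound 3 gives a limit, > 12000 nM, and the earlier step was unreadable, the step that the limit leaves unreadable from compound 3 to compound 4 is expected to be small. Compound 4 is estimated at 20000 nM in this assay, most likely again only a limit.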

Compound 4, half-maximal cytotoxic concentration: > 12000 nM
Compound 4 gave a limit, no number; the forecaster's own chance of this, stated with the estimate: 75%; the middle value does not contradict the limit.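

In this assay, within the data shown here, compound 4 gives only a limit, > 12000 nM, so no step from compound 3 to compound 4 can be read. The compounds shown leave open whether methyl in place of hydrogen changes cytotoxicity at all.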